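The compounds below may be only part of what the source reports. "The series", "measured", "known", "first", "only" and "open" are said of these compounds alone.

Compound 2 `CNC1=CC(=O)c2cc(C)ncc2C1=O` gives 7640 nM in a functional assay on OVCAR-3 cells (Homo sapiens) for cytotoxicity, read by propidium iodide staining, with a stated time of 4 days (a higher number here means a weaker inhibitor, a lower number a stronger inhibitor), the lower of the two numbers in hand; compound 1 `CNC1=CC(=O)c2c(cnc(C)c2C)C1=O` gives 32300 nM. Among the compounds with values here, the only measured step, a 4.2-fold lower number from compound 1 to compound 2 (0.63 log units; beyond the scatter), concerns hydrogen in place of methyl on an aromatic carbon. Compound 3 `Cc1cc2c(cn1)C(=O)C(NCl)=CC2=O` differs from compound 2 by chloro in place of methyl on an amine nitrogen. Within the data shown here, no measured step touches the amine nitrogen, so that single aromatic-carbon step gives little guidance, and a modest step in either direction cannot be ruled out. The estimate for compound 3 in this assay is 7000 nM, expected to fall between 1500 nM and 35000 nM. This estimate corresponds to an expected step of a 1.1-fold lower number from compound 2 to compound 3 (0.04 log units; within the scatter).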

Compound 3, half-maximal inhibitory concentration: 2000 nM
Compound 3: middle estimate off by 3.5-fold (0.54 log units), on the high side; measured number inside the range.
By their numbers in this assay, from the lowest: compound 3; then compound 2; then compound 1.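

Chloro in place of methyl on an amine nitrogen gives a 3.8-fold lower number from compound 2 to compound 3 (0.58 log units; beyond the scatter) in this assay and so provides the first reading at this position. The amine nitrogen is therefore not silent to substitution in this assay, and the series now has a second place where a single change lowers the number. No measurement in hand accounts for this shift.

As far as these compounds go, whether an unsubstituted amine, an ethyl group or a longer chain on that nitrogen would lower the number further remains open. Also open, from the compounds shown here alone, is whether the chloro step would carry over to the core of compound 1.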